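The source may hold more compounds than are shown below. What is called first, only, known or untested is meant among the compounds shown, and "the series" means these compounds.

Measured in an ADME assay on RAW264.7 cells (Mus musculus) for cytotoxicity, read by MTT assay, with a stated time of 24 h; a higher number here means that more compound is tolerated, a lower number that less compound is tolerated:
Compound 1 `CC/C=C\C[C@H]1C(=O)C=C[C@H]1CC(=O)Oc1ccccc1`: 158 uM
Compound 2 `CC/C=C\C[C@H]1C(=O)C=C[C@H]1CC(=O)OC(C)C`: 58 uM

Compound 2, at 58 uM, holds the lower of these two numbers. Compound 3 `CC/C=C\C[C@H]1C(=O)C=C[C@H]1CC(=O)OC(C)COC` differs from it by one change: methoxy in place of hydrogen on a saturated chain carbon, two bonds along the chain from an oxygen next to a carbonyl group. Among the measured compounds shown here, only one measured step bears on this, a 2.7-fold lower number from compound 1 to compound 2 (0.44 log units; beyond the scatter), a modest change that also fell on the group at that oxygen. It swapped isopropyl for phenyl, a different change, so it hints at size but not direction. In this assay, no step beyond the scatter is therefore expected. The expected step is a 1.1-fold higher number from compound 2 to compound 3 (0.05 log units; within the scatter). For compound 3, the estimated value is 65 uM, with an expected range of 28 uM to 150 uM.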

Compound 3, half-maximal toxic concentration: 161 uM
The estimate for compound 3 lay 2.5-fold (0.39 log units) below the measured number; the whole stated range lies below it.
By their numbers in this assay, from the lowest: compound 2; then compounds 1 and 3 (each within the scatter of the next).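

In this assay, adding methoxy at this saturated chain carbon gives a 2.8-fold higher number from compound 2 to compound 3 (0.44 log units; beyond the scatter), so a small addition two bonds along the chain from the oxygen can shift how much compound is tolerated. With 1-(methoxymethyl)ethyl in place of phenyl, the result is a 1.0-fold higher number from compound 1 to compound 3 (0.01 log units; within the scatter), which leaves compound 2 alone apart from the other two. No supporting measurement explains this shift. From the compounds shown here alone, it remains open whether a hydroxyl group, an amine or a longer chain at the same carbon would give a similar step.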